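A 4-nitrophenyl group on a sulfonyl sulfur

A few compounds are considered here, and "the series" means these few. Any claim that something is new, unique, unknown or untested is made for them only; others in the source may bear on it.

Compound 1 `COc1ccc(S(=O)(=O)n2c(-c3cn(-c4ccccc4)nc3-c3ccc(F)cc3)nc3ccccc32)cc1` gives 470 nM
Compound 2 `Cc1ccc(C)c(S(=O)(=O)n2c(-c3cn(-c4ccccc4)nc3-c3ccc(F)cc3)nc3ccccc32)c1` gives 410 nM

Going by the values given here, in a functional assay on HepG2 cells (Homo sapiens) for antiproliferative activity, read by MTT assay, with a stated time of 24 h (a higher number here means a weaker inhibitor, a lower number a stronger inhibitor), compound 2 cannot be told apart from compound 1, the only other measured compound. Compound 3 `O=[N+]([O-])c1ccc(S(=O)(=O)n2c(-c3cn(-c4ccccc4)nc3-c3ccc(F)cc3)nc3ccccc32)cc1` differs from compound 2 by 4-nitrophenyl in place of 2,5-dimethylphenyl on a sulfonyl sulfur, with 4-nitrophenyl in place of 2,5-dimethylphenyl on a sulfonyl sulfur. One measured step changes the group at this place: a 1.1-fold lower number from compound 1 to compound 2 (0.06 log units; within the scatter). Among the compounds with values here, no measured compound carries 4-nitrophenyl, so that small step is weak guidance. The expected change is a 1.0-fold higher number from compound 2 to compound 3 (0.02 log units; within the scatter), with no step beyond the scatter expected in this assay. For compound 3 the estimated value is 430 nM, with an expected range of 200 nM to 900 nM.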

Compound 3, half-maximal inhibitory concentration: 1340 nM
Beside the measured number, compound 3's estimate is 3.1-fold (0.49 log units) below it; the measured number lies above the stated range.
By their numbers in this assay, from the lowest: compounds 2 and 1 (each within the scatter of the next); then compound 3.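

In this assay the group on the sulfonyl sulfur proves not to be freely exchangeable: 4-nitrophenyl in place of 2,5-dimethylphenyl gives a 3.3-fold higher number from compound 2 to compound 3 (0.51 log units; beyond the scatter), and nitro in place of methoxy on an aromatic carbon gives a 2.9-fold higher number from compound 1 to compound 3 (0.46 log units; beyond the scatter). Going by these compounds alone, these are the first steps at this position to lie beyond the scatter, and both run in the same direction. No evidence at hand bears on what lies behind them. The compounds shown leave open whether the rise is particular to nitro or would also come with an amine or a carboxylic acid on that aromatic carbon. They also leave open whether an unsubstituted phenyl on the sulfonyl sulfur would fall with compound 3 or with compound 1 and compound 2.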